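Amide aryl trimming from compound 2 to compound 4

This account rests on a few compounds, and the source may have more. Where it says the series, first, only, none or still open, it means among the compounds named here.

Measured values in a functional assay on ACHN cells (Homo sapiens) for inhibition, read by sulforhodamine B assay, with a stated time of 48 h; a higher number here means a weaker inhibitor of growth, a lower number a stronger inhibitor of growth:
compound 1 `O=C(Nc1cccc(-n2cc(-c3ccncc3)c(-c3ccc(Cl)c(O)c3)n2)c1)Nc1ccc(Cl)c(Cl)c1` gives > 32500 nM, a limit of the assay.
compound 2 `COc1cc(-c2nn(-c3cccc(NC(=O)c4ccc(Cl)c(C(F)(F)F)c4)c3)cc2-c2ccncc2)ccc1Cl` gives > 32500 nM, a limit of the assay.
compound 3 `COc1cc(-c2nn(-c3cccc(NC(=O)c4cccc(C(F)(F)F)c4)c3)cc2-c2ccncc2)ccc1Cl` gives > 50000 nM, a limit of the assay.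

Among the compounds with values here, compound 2 stands only at a limit in this assay, and the two other values shown are limits as well, so no compound in the set has a numbered value. Within the data shown here, the one change that pairs two measured compounds is a step that the two limits leave unreadable from compound 2 to compound 3. Both ends of that pair sit at limits, so the size of the step is not readable. Compound 4 `COc1cc(-c2nn(-c3cccc(NC(=O)c4ccccc4)c3)cc2-c2ccncc2)ccc1Cl` differs from compound 2 by phenyl in place of 4-chloro-3-(trifluoromethyl)phenyl on a carbonyl carbon. Compound 1 and compound 2 share the same limit (the limit of > 32500 nM in this assay, at which 2 of the 3 values shown sit) with quite different groups on the amide side, and compound 3 also sits at a limit (the limit of > 50000 nM in this assay, at which 1 of the 3 values shown sits) once the chloro is gone. Nothing measured suggests that taking away the chloro and the trifluoromethyl together would bring the value into the readable range. The step from compound 2 to compound 4 is expected to be a step that the limit leaves unreadable from compound 2 to compound 4, that is, no readable change. Compound 4 is therefore expected at 40000 nM, within 15000 nM to 100000 nM, and most likely reported as a limit again.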

Compound 4, concentration for total growth inhibition: > 100000 nM
Compound 4: only a limit was reported; the forecaster's own chance of this, stated with the estimate: 75%; at least 2.5-fold (0.39 log units) between middle value and limit.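

In this assay compound 4 gives > 100000 nM, which is a limit of the assay. The steps to compound 4 from compound 2 and from compound 3 have limits at both ends, so neither can be read. The compounds shown leave open whether any group on the amide carbonyl gives a numbered value here.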